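The compounds below may be only part of what the source reports. "The series", "measured", "known", "first", "only" and "open" are said of these compounds alone.

Of the compounds shown here, three sharing one core have been measured in a functional assay on NCI-H23 cells (Homo sapiens) for inhibition, read by sulforhodamine B assay, with a stated time of 48 h; a lower number here means a stronger inhibitor of growth, a higher number a weaker inhibitor of growth. Compound 1 (`CCCCCCCCCCCC[C@@H](O)[C@H]1CC[C@H]([C@H](O)CCCCCCCCCCNC(=O)c2ccnn2C)O1`) gives 52.5 nM, compound 2 (`CCCCCCCCCCCC[C@@H](O)[C@H]1CC[C@H]([C@H](O)CCCCCCCCCCN(C)C(=O)c2ccnn2C)O1`) gives 240 nM, and compound 3 (`CCCCCCCCCCCC[C@@H](O)[C@H]1CC[C@H]([C@H](O)CCCCCCCCCCNCc2ccnn2C)O1`) gives 646 nM, the highest number of the three. Compound 4 (`CCCCCCCCCCCC[C@@H](O)[C@H]1CC[C@H]([C@H](O)CCCCCCCCCCC(=O)Nc2ccnn2C)O1`) has not yet been measured. It differs from compound 3 as follows: (1-methyl-1H-pyrazol-5-yl)carbamoyl in place of ((1-methyl-1H-pyrazol-5-yl)methyl)amino on a saturated chain carbon, ten or more bonds along the chain from an oxygen on a saturated carbon and a saturated ring carbon. In words, (1-methyl-1H-pyrazol-5-yl)carbamoyl stands in place of ((1-methyl-1H-pyrazol-5-yl)methyl)amino on a saturated chain carbon. Among the compounds with values here, no measured step tests this exact change. The closest guide is the large step of a 12-fold higher number from compound 1 to compound 3 (1.09 log units; beyond the scatter), with (1-methyl-1H-pyrazol-5-yl)methyl in place of (1-methyl-1H-pyrazol-5-yl)carbonyl. The modest step of a 4.6-fold higher number from compound 1 to compound 2 (0.66 log units; beyond the scatter), with methyl in place of hydrogen on an amide-type nitrogen, also bears on it. Compound 4 carries a carbonyl and an amide hydrogen, as compound 1 does, although its amide is not the same one. In this assay the expected step is a 5.0-fold lower number from compound 3 to compound 4 (0.70 log units; beyond the scatter), towards a lower number and of modest size. For compound 4 the estimated value is 130 nM, with an expected range from 40 nM to 450 nM.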

Compound 4, concentration for 50% growth inhibition: 26900 nM
Compound 4: the middle estimate sits 210-fold (2.32 log units) below what was measured; measured number above the stated range.
By their numbers in this assay, from the lowest: compound 1; then compound 2; then compound 3; then compound 4.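

In this assay, carrying a carbonyl and an amide hydrogen proves not to be enough, since moving to the (1-methyl-1H-pyrazol-5-yl)carbamoyl group gives a 510-fold higher number from compound 1 to compound 4 (2.71 log units; beyond the scatter). The same change also falls well behind the groups with a weaker number than compound 1, with a 110-fold higher number from compound 2 to compound 4 (2.05 log units; beyond the scatter) and a 42-fold higher number from compound 3 to compound 4 (1.62 log units; beyond the scatter), so at this end of the chain the orientation of the amide counts for more than anything the three earlier compounds varied, and even the amine of compound 3 outperforms the turned amide. No measured evidence accounts for this loss.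

The compounds shown leave open whether ((1-methyl-1H-pyrazol-5-yl)methyl)carbamoyl, with its extra methylene, would regain the lost ground. They also leave open how a urea or a sulfonamide would behave on the same saturated chain carbon.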